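The source may hold more compounds than are shown below. What is called first, only, known or untested is meant among the compounds shown, and "the series" means these compounds.

The measured compounds in this study:
Compound 1, `CC1=CSC(O)(c2ccc([N+](=O)[O-])cc2)c2noc(=O)n21`. In a functional assay on A2780/DX3 cells (Homo sapiens) for antiproliferative activity, read by MTT assay, with a stated time of 3 days (on this read-out lower numbers stand for stronger inhibition and higher numbers for weaker inhibition), compound 1 reaches only the limit > 100000 nM, a limit of the assay (the limit of > 100000 nM in this assay, at which 1 of the 3 values shown sits).
Compound 2, `CC1=CSC(O)(c2cccc([N+](=O)[O-])c2)c2noc(=O)n21`. In this assay compound 2 gives 129000 nM.
Compound 3, `CC1=CSC(O)(c2cccc(C(F)(F)F)c2)c2noc(=O)n21`. In this assay compound 3 gives 71000 nM.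

Compound 3 therefore holds the lowest of the two numbers in this assay, with compound 2 as its nearest neighbour; the step of a 1.8-fold lower number from compound 2 to compound 3 (0.26 log units; within the scatter) is within the scatter. The value of compound 1 is a limit and not a number, so it sets no order against the other two.

Compound 4, `CC1=CSC(O)(c2ccccc2)c2noc(=O)n21`, differs from compound 3 in one place: hydrogen in place of trifluoromethyl on an aromatic carbon. Among the compounds with values here, only one measured step touches that position, the exchange a 1.8-fold lower number from compound 2 to compound 3 (0.26 log units; within the scatter), and it stayed within the scatter. Both measured groups at that position sit near the upper edge of what this assay reports, and the whole set lies in a narrow band. The expectation for compound 4 is therefore a step of a 1.2-fold higher number from compound 3 to compound 4 (0.08 log units; within the scatter), that is, none beyond the scatter in either direction. Compound 4 is accordingly estimated at 85000 nM in this assay, within a range of 30000 nM to 200000 nM, with a fair chance that only a limit is reported.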

Compound 4, half-maximal inhibitory concentration: > 100000 nM
Compound 4: a limit, no number; the forecaster's own chance of this, stated with the estimate: 30%; middle value at least 1.1-fold (0.07 log units) from the limit.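

On these data alone, exchanging trifluoromethyl for hydrogen on this aromatic carbon gives an at least 1.4-fold higher number from compound 3 to compound 4 (0.14 log units; that floor lies within the scatter) in this assay, so the position now has a reference with no group on it, yet the floor of that step cannot be told apart from the usual variation between repeats and the true size of the step stays unknown. Compound 4 reaches only a limit of the assay, > 100000 nM, so the data do not show that trifluoromethyl contributes anything at this place, and they do not rule it out either. The steps from compound 1 and from compound 2 to compound 4 cannot be read, which leaves the exchange from compound 3 as the only one with even a floor, and the series now rests in part at the edge of the read-out: the limit of > 100000 nM in this assay, at which 2 of the 4 values shown sit.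

The compounds shown leave open whether another group on this aromatic carbon, such as an amine, a carboxylic acid or a methoxy group, would move the number clearly away from that limit. They also leave open whether changing the methyl or the hydroxyl on the shared core would do so.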